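The source may hold more compounds than are shown below. What is called first, only, known or untested is meant among the compounds shown, and "the series" means these compounds.

Of the compounds shown here, three have been measured in a functional assay on isolated protein for agonist activity at Glucose-dependent insulinotropic receptor (Homo sapiens), read by HTRF and cAMP accumulation; on this read-out higher numbers stand for an effect only at larger amounts of compound and lower numbers for an effect already at smaller amounts. Compound 1 `Cc1nc(O[C@H]2CC[C@H](OC3CCN(C(=O)OC(C)(C)C)CC3)CC2)ccc1C(=O)N(C)C` gives 262 nM. Compound 2 `CC(C)(C)OC(=O)N1CCC(O[C@H]2CC[C@H](Oc3cnc(S(C)(=O)=O)cn3)CC2)CC1` gives 5.9 nM, and compound 3 `CC1(OC(=O)N2CCC(O[C@H]3CC[C@H](Oc4cnc(S(C)(=O)=O)cn4)CC3)CC2)CC1` gives 25.9 nM. On these numbers compound 3 stands second highest of the three: its nearest neighbour is compound 2, whose value is lower, while compound 1 is the furthest away with the highest value. Among the measured compounds shown here, the one step that connects two of them in a single place is a 4.4-fold higher number from compound 2 to compound 3 (0.64 log units; beyond the scatter), so swapping the group on the oxygen next to the carbonyl has moved the number, though only moderately.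

Compound 4 `CS(=O)(=O)c1cnc(O[C@H]2CC[C@H](OC3CCN(C(=O)OC4CCOC4)CC3)CC2)cn1` is not yet measured. It differs from compound 3 by oxolan-3-yl in place of 1-methylcyclopropyl on an oxygen next to a carbonyl group. For the measured compounds named here, only the step from compound 2 to compound 3 bears on this, since it alters the same group on the same oxygen next to the carbonyl, and it was modest in size. Going by the values given here, no measured pair shows what a ring with an oxygen in it does at this place, so the direction is uncertain. For compound 4 in this assay a step of about a 1.2-fold higher number from compound 3 to compound 4 (0.06 log units; within the scatter) is expected, a small change that may well fall within the scatter. Compound 4 is therefore estimated at 30 nM, with a likely range from 8 nM to 120 nM.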

Compound 4, half-maximal effective concentration: 427 nM
Compound 4: the middle estimate sits 14-fold (1.15 log units) below what was measured, outside the stated range (above it).
By their numbers in this assay, from the lowest: compound 2; then compound 3; then compounds 1 and 4 (each within the scatter of the next).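

In this assay, among the compounds shown here, the group on the oxygen next to a carbonyl group proves able to move the number much further than the first swap at this place showed: oxolan-3-yl in place of 1-methylcyclopropyl gives a 16-fold higher number from compound 3 to compound 4 (1.22 log units; beyond the scatter), and oxolan-3-yl in place of tert-butyl gives a 72-fold higher number from compound 2 to compound 4 (1.86 log units; beyond the scatter). This change does more than one thing at once, since a three-membered ring of carbon only leaves and a five-membered ring with one oxygen and one hydrogen-bond acceptor enters, so the place clearly does not accept every ring equally. No measurement shown gives a reason for the size of this step.

The compounds shown leave open whether the ring oxygen, the ring size or the loss of the 1-methylcyclopropyl shape itself carries the step, and a cyclopentyl group at the same place would help separate these, as it keeps the five-membered ring without the oxygen. On these data alone, it also remains open whether oxolan-3-yl would shift the number as far on the core of compound 1, and whether a smaller ring with oxygen, such as oxetan-3-yl, would behave in the same way.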